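The compounds below may be only part of what the source reports. "The series", "measured", "known", "first", "only" and "open" are said of these compounds alone.

Measured in a functional assay on NB1 cells (Homo sapiens) for antiproliferative activity, with a stated time of 72 h; a lower number here means a stronger inhibitor, a higher number a weaker inhibitor
compound 1 (`Cc1ccc(NC(=O)CCN(Cc2ccc(C(=O)NO)cc2)C(=O)c2cc(C)cc(C)c2)cc1`) gives 670 nM
compound 2 (`Cc1cc(C)cc(C(=O)N(CCC(=O)NCc2ccccc2)Cc2ccc(C(=O)NO)cc2)c1`) gives 3870 nM
compound 3 (`Cc1ccc(CNC(=O)CCN(Cc2ccc(C(=O)NO)cc2)C(=O)c2ccc(N(C)C)cc2)cc1`) gives 700 nM

Compound 2 has the highest number of the three, with compound 1 and compound 3 both lower by more than the scatter. Compound 4 (`COc1cc(OC)cc(C(=O)N(CCC(=O)NCc2ccccc2)Cc2ccc(C(=O)NO)cc2)c1`) departs from compound 2 at one place: 3,5-dimethoxyphenyl in place of 3,5-dimethylphenyl on a carbonyl carbon. Among the compounds with values here, the only measured single-place step, a 5.8-fold higher number from compound 1 to compound 2 (0.76 log units; beyond the scatter), concerns an amide-type nitrogen, so it offers a rough size scale and no direct precedent. Compound 3 differs from compound 2 in more than one place. In this assay no shift beyond the scatter is expected, and the direction is open. The expected step is a 1.3-fold lower number from compound 2 to compound 4 (0.11 log units; within the scatter), which stays inside the scatter. Compound 4 is expected at 3000 nM, within an estimated range of 1100 nM to 8000 nM here.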

Compound 4, half-maximal inhibitory concentration: 13300 nM
For compound 4 the middle estimate is 4.4-fold (0.65 log units) below the measured one; measured number outside the range, above it.
By their numbers in this assay, from the lowest: compounds 1 and 3 (each within the scatter of the next); then compound 2; then compound 4.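

In this assay, the group on the carbonyl carbon proves able to move the number: 3,5-dimethoxyphenyl in place of 3,5-dimethylphenyl gives a 3.4-fold higher number from compound 2 to compound 4 (0.54 log units; beyond the scatter) in the series. The earlier single-place step concerned only an amide-type nitrogen, so this is the first single-place change shown on the carbonyl side. Nothing measured here accounts for the shift.

As far as these compounds go, whether the same change has a similar effect with 4-methylphenyl on the amide-type nitrogen remains open. Also open, from the compounds shown here alone, is how 3,5-dichlorophenyl would compare at this carbonyl carbon.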